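Halogen swap on the ester-bearing ring of a flavone series

The source may hold more compounds than are shown below. What is called first, only, known or untested is meant among the compounds shown, and "the series" means these compounds.

Compound 1 `COC(=O)c1cc(Cl)ccc1OC(=O)COc1cc(O)c2c(=O)cc(-c3ccccc3)oc2c1`: 3740 nM
Compound 2 `COC(=O)c1ccc(C)cc1OC(=O)COc1cc(O)c2c(=O)cc(-c3ccccc3)oc2c1`: 31100 nM
Compound 3 `COC(=O)c1cc(F)ccc1OC(=O)COc1cc(O)c2c(=O)cc(-c3ccccc3)oc2c1`: 6820 nM

In a functional assay on cells (T-cell, Mus musculus, strain BALB/c) for inhibition, read by MTT assay, with a stated time of 72 h (on this read-out higher numbers stand for weaker inhibition and lower numbers for stronger inhibition), compound 3 gives 6820 nM, the second highest of the three numbers. Its nearest neighbour is compound 1 with 3740 nM, and the step of a 1.8-fold higher number from compound 1 to compound 3 (0.26 log units; within the scatter) lies within the scatter. Compound 2 gives 31100 nM, and the step of a 4.6-fold lower number from compound 2 to compound 3 (0.66 log units; beyond the scatter) is modest but beyond the scatter.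

Compound 4 `COC(=O)c1ccc(Br)cc1OC(=O)COc1cc(O)c2c(=O)cc(-c3ccccc3)oc2c1` differs from compound 3 by a group of 11 heavy atoms (8 carbon, 2 oxygen, 1 bromine; one six-membered aromatic ring of carbon only) in place of a group of 11 heavy atoms (8 carbon, 2 oxygen, 1 fluorine; one six-membered aromatic ring of carbon only), on an oxygen next to a carbonyl group. The entering group carries bromine where the leaving one carried fluorine, and the bromine sits on the ring where compound 2 carries its methyl rather than where compound 1 and compound 3 carry their halogen. Going by the values given here, two steps bear on this: a 1.8-fold higher number from compound 1 to compound 3 (0.26 log units; within the scatter) shows that exchanging one halogen for another at a shared place changes little, while an 8.3-fold higher number from compound 1 to compound 2 (0.92 log units; beyond the scatter) shows that moving to the other substitution pattern of that ring weakened inhibition. Compound 4 is therefore expected to fall between these outcomes, with a step of a 1.8-fold higher number from compound 3 to compound 4 (0.25 log units; within the scatter) toward a higher number, though the uncertainty is wide. The estimate for compound 4 is 12000 nM, within a range of 3500 nM to 40000 nM.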

Compound 4, half-maximal inhibitory concentration: 17600 nM
Beside the measured number, compound 4's estimate is 1.5-fold (0.17 log units) below it, and the stated range covers the measured number.
By their numbers in this assay, from the lowest: compounds 1 and 3 (each within the scatter of the next); then compounds 4 and 2 (each within the scatter of the next).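

In this assay, bromo in place of methyl on an aromatic carbon gives a 1.8-fold lower number from compound 2 to compound 4 (0.25 log units; within the scatter), so at this carbon the two groups cannot be told apart. Compound 4 nevertheless stays separate from both compounds that carry their halogen elsewhere on the ring, with a 2.6-fold higher number from compound 3 to compound 4 (0.41 log units; beyond the scatter) and a 4.7-fold higher number from compound 1 to compound 4 (0.67 log units; beyond the scatter), each modest but beyond the scatter. Carrying a halogen is thus not enough to bring the number down to the level of compound 1 and compound 3, and among these four compounds the numbers fall into two groups that follow the substitution pattern of the ring, with no compound going against this; nothing measured alongside these numbers gives a reason for that grouping.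

The compounds shown leave open how much of the steps from compound 1 and compound 3 to compound 4 belongs to the identity of the halogen and how much to its place on the ring, as each of these pairs changes both at once. Also open, on these data alone, is how the number would respond to a different kind of group on this ring, such as an amine or a carboxylic acid.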